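Cyclopentylamino to cyclopropylamino: cytotoxicity on Vero cells

The source may hold more compounds than are shown below. What is called first, only, known or untested is meant among the compounds shown, and "the series" means these compounds.

compound 1 `Fc1ccc(-c2nc3ccc(NC4CCCC4)cn3c2-c2ccnc(NC3CCCC3)n2)cc1`: > 40000 nM (a limit)
compound 2 `Cc1cc(NC2CCCC2)cn2c(-c3ccnc(NC4CCCC4)n3)c(-c3ccc(F)cc3)nc12`: > 40000 nM (a limit)

In an ADME assay on Vero cells (Chlorocebus sabaeus) for cytotoxicity (on this read-out lower numbers stand for higher toxicity in this test and higher numbers for lower toxicity in this test), compound 1 gives > 40000 nM, which is a limit of the test and not a number. Compound 2 likewise gives > 40000 nM, again a limit. Within the data shown here, the only measured step, a step that the two limits leave unreadable from compound 1 to compound 2, is therefore unreadable, and all that the numbers show is the limit of > 40000 nM in this assay, at which 2 of the 2 values shown sit. Compound 3 `Cc1cc(NC2CC2)cn2c(-c3ccnc(NC4CCCC4)n3)c(-c3ccc(F)cc3)nc12` is not yet measured; it carries cyclopropyl in place of cyclopentyl on a nitrogen on an aromatic ring. Among the measured compounds shown here, no measured step bears on this change, so no shift beyond the scatter is expected in this assay. Compound 3 is expected to give 40000 nM in this assay, within 20000 nM to 80000 nM, most likely again as a limit. The expected step is a number no higher from compound 2 to compound 3 (the limit leaves the size open).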

Compound 3, half-maximal cytotoxic concentration: > 40000 nM
Compound 3 gave a limit, no number; the forecaster's own chance of this, stated with the estimate: 85%; the middle value sits exactly at the limit.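

In this assay compound 2 gives > 40000 nM, a limit and not a number. Among these compounds, compound 3 gives > 40000 nM, also a limit, so no step between compound 2 and compound 3 can be read. The compounds shown leave open what actual half-maximal cytotoxic concentration each compound has, and whether cyclopropyl in place of cyclopentyl shifts it.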